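Shortening the propyl chain: compound 3 to compound 4

The compounds below may be only part of what the source reports. "The series", "measured", "known", "first", "only" and "open" are said of these compounds alone.

In a functional assay on the whole organism for inhibition, with Mus musculus as the target, read by paw edema, with a stated time of 180 min, at a dose of 200 mg/kg by the oral route (a higher number here means a stronger effect of the compound at the dose given, a lower number a weaker effect), the three measured compounds give:
compound 1 `CNc1nnc(Cn2c(=O)oc3ccc(C)cc32)s1`: 46.9%
compound 2 `Cc1ccc2oc(=O)n(CC(=O)NN)c2c1`: 70.5%
compound 3 `CCCNC(=S)NNC(=O)Cn1c(=O)oc2ccc(C)cc21`: 25.1%

Compound 3 stands lowest of the three; compound 1 sits higher and compound 2 higher still, both beyond the scatter. Within the data shown here, the only step between two measured compounds is a number 45.4 percentage points lower from compound 2 to compound 3 (beyond the scatter), where a whole chain group replaces a hydrogen on an amine nitrogen.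

Compound 4 `CCNC(=S)NNC(=O)Cn1c(=O)oc2ccc(C)cc21` differs from compound 3 in one place: hydrogen in place of methyl on a saturated chain carbon, two bonds along the chain from an amide-type nitrogen. Among the measured compounds shown here, no measured step shortens a chain by one carbon; the step from compound 2 to compound 3 adds the entire group and so gives no guide to trimming it. With nothing to point either way, the expected step is a number 1.9 percentage points higher from compound 3 to compound 4 (within the scatter), none beyond the scatter. Compound 4 is estimated at 27%, with a range from 14% to 42%.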

Compound 4, a percentage reported as inhibition, in the whole organism at one dose (the size of the read-out at that dose, not a potency): 54.6%
Estimate against measurement, compound 4: 27.6 percentage points below, and the stated range ends below it.
By their numbers in this assay, from the lowest: compound 3; then compounds 1 and 4 (each within the scatter of the next); then compound 2.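

In this assay, removing one methyl from the chain gives a number 29.5 percentage points higher from compound 3 to compound 4 (beyond the scatter) in a single step, so this chain carbon matters and the effect of the added group depends on its length, not just on its presence. Even so, the ethyl compound does not fully match the parent hydrazide, with a number 15.9 percentage points lower from compound 2 to compound 4 (beyond the scatter) on the amine nitrogen. Nothing at hand explains why one carbon changes the read-out this much.

Still open, from the compounds shown here alone, is how methylamino or butylamino in this place would read, and whether a branched chain such as isopropyl would follow propyl or ethyl.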